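A few compounds are considered here, and "the series" means these few. Any claim that something is new, unique, unknown or untested is made for them only; others in the source may bear on it.

Measured so far:
compound 1, `Brc1ccc(C2=NN(C3=NC(c4ccccc4)CS3)C(c3ccc4ccccc4c3)C2)cc1`, gives 4960 nM in a functional assay on HeLa cells (Homo sapiens) for inhibition, read by CCK-8 assay, with a stated time of 48 h; a higher number here means a weaker inhibitor, a lower number a stronger inhibitor
compound 2, `Clc1ccc(C2=NN(C3=NC(c4ccccc4)CS3)C(c3cccc4ccccc34)C2)cc1`, gives 9940 nM in this assay
compound 3, `Brc1ccc(C2=NN(C3=NC(c4ccccc4)CS3)C(c3cccc4ccccc34)C2)cc1`, gives 6650 nM in this assay

All three values lie within the scatter of one another, so no order among them is claimed. Compound 2 and compound 3 share the same naphthyl group and differ only at the aromatic carbon, (chloro in place of bromo on an aromatic carbon); the step of a 1.5-fold lower number from compound 2 to compound 3 (0.17 log units; within the scatter) is within the scatter.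

Compound 4, `Clc1ccc(C2=NN(C3=NC(c4ccccc4)CS3)C(c3ccc4ccccc4c3)C2)cc1`, is not yet measured. It differs from compound 2 by naphthalen-2-yl in place of naphthalen-1-yl on a saturated ring carbon. The same kind of change is made from compound 3 to compound 1, (naphthalen-2-yl in place of naphthalen-1-yl on a saturated ring carbon), where it gave a 1.3-fold lower number from compound 3 to compound 1 (0.13 log units; within the scatter). The two places are not identical word for word: the ring atom two ring bonds away bears a 4-bromophenyl group in the pair of compound 3 and compound 1, and a 4-chlorophenyl group in the pair of compound 2 and compound 4; the two cores differ by chloro in place of bromo on an aromatic carbon.

The step from compound 2 to compound 4 is expected to be a 1.3-fold lower number from compound 2 to compound 4 (0.12 log units; within the scatter), resting on compound 3 to compound 1 having given a 1.3-fold lower number from compound 3 to compound 1 (0.13 log units; within the scatter). Compound 4 is therefore estimated at 7600 nM in this assay, expected to fall between 3500 nM and 16000 nM.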

Compound 4, half-maximal inhibitory concentration: 7560 nM
For compound 4 the middle estimate is 1.0-fold (0.00 log units) above the measured one; measured number inside the range.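

In this assay, naphthalen-2-yl in place of naphthalen-1-yl on the saturated ring carbon gives a 1.3-fold lower number from compound 2 to compound 4 (0.12 log units; within the scatter), and this step matches the one seen with the 4-bromophenyl group: the same change on two cores in this assay, a 1.3-fold lower number (0.13 log units; within the scatter) from compound 3 to compound 1 and a 1.3-fold lower number (0.12 log units; within the scatter) from compound 2 to compound 4, 1.0-fold (0.01 log units) apart, within the scatter of two such steps. Chloro in place of bromo on the aromatic carbon reads the same way, with a 1.5-fold higher number from compound 1 to compound 4 (0.18 log units; within the scatter) set beside the earlier step between the naphthalen-1-yl compounds: the same change on two cores in this assay, a 1.5-fold lower number (0.17 log units; within the scatter) from compound 2 to compound 3 and a 1.5-fold lower number (0.18 log units; within the scatter) from compound 4 to compound 1, 1.0-fold (0.01 log units) apart, within the scatter of two such steps. Within the data shown here, since every step lies within the scatter, the agreement shows only that neither change gave a measurable shift on either core; it does not establish a real effect of either change that carries from core to core, or any behaviour outside these four compounds.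

On these data alone, the four compounds vary only between chloro and bromo and between the two naphthyl attachments, so a wider range of groups remains untested here. As far as these compounds go, it stays open whether an amine, a carboxylic acid or a longer chain in place of the halogen would move the number beyond the scatter.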